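The source may report more compounds than this note shows. Statements on the series, on what has been measured and on what is new or still open speak of the compounds shown alone.

Measured so far in a functional assay on DU-145 cells (Homo sapiens) for cytotoxicity, read by MTT assay; a lower number here means a stronger inhibitor, a higher number a weaker inhibitor:
Compound 1 `CC(C)=CC[C@@H](OC(=O)c1ccoc1)C1=CC(=O)c2c(O)ccc(O)c2C1=O` reaches only the assay limit, > 100000 nM.
Compound 2 `CC[C@](C)(O)CC(=O)O[C@H](CC=C(C)C)C1=CC(=O)c2c(O)ccc(O)c2C1=O` gives 20500 nM.
Compound 3 `CC(C)=CC[C@@H](OC(=O)CCO)C1=CC(=O)c2c(O)ccc(O)c2C1=O` gives 55300 nM.

Compound 3 holds the highest of the two real numbers; its nearest neighbour is compound 2, with a 2.7-fold higher number from compound 2 to compound 3 (0.43 log units; beyond the scatter). Compound 1 sits at a limit (the limit of > 100000 nM in this assay, at which 1 of the 3 values shown sits), so an at least 4.8-fold lower number from compound 1 to compound 2 (0.68 log units; beyond the scatter) and an at least 1.8-fold lower number from compound 1 to compound 3 (0.25 log units; that floor lies within the scatter) are floors only. All three measured steps vary the group on a carbonyl carbon of the ester. Compound 4 `CC(C)=CC[C@@H](OCCO)C1=CC(=O)c2c(O)ccc(O)c2C1=O` removes that carbonyl: 2-hydroxyethyl in place of (2-hydroxyethyl)carbonyl on an oxygen on a saturated carbon. No measured step touches this position, so nothing shown tells the direction; the change is taken as roughly neutral in this assay, with wide uncertainty. Compound 4 is therefore expected near 70000 nM, between 25000 nM and 200000 nM, which means a 1.3-fold higher number from compound 3 to compound 4 (0.10 log units; within the scatter).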

Compound 4, half-maximal inhibitory concentration: 9900 nM
Beside the measured number, compound 4's estimate is 7.1-fold (0.85 log units) above it, and the stated range ends above it.
By their numbers in this assay, from the lowest: compound 4; then compound 2; then compound 3. At a limit, above all of these: compound 1.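

In this assay, the ester carbonyl proves dispensable at this position: replacing (2-hydroxyethyl)carbonyl with 2-hydroxyethyl on the oxygen gives a 5.6-fold lower number from compound 3 to compound 4 (0.75 log units; beyond the scatter). The change also passes the lowest ester value shown, with a 2.1-fold lower number from compound 2 to compound 4 (0.32 log units; beyond the scatter), a larger effect than the measured swaps of ester side chain alone would suggest. The third step, an at least 10-fold lower number from compound 1 to compound 4 (1.00 log units; beyond the scatter), is a floor only: the limit of > 100000 nM in this assay, at which 1 of the 4 values shown sits.

On these data alone, it remains open whether the terminal hydroxyl contributes to this gain. A plain ethyl, a 2-aminoethyl or a longer 3-hydroxypropyl chain on that oxygen could settle this.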